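The source may hold more compounds than are shown below. What is called first, only, known or untested is meant among the compounds shown, and "the series" means these compounds.

Measured compounds in a functional assay on MCF7 cells (Homo sapiens) for antiproliferative activity, read by MTT assay, with stated times of 24 h and 72 h; a higher number here means a weaker inhibitor, a lower number a stronger inhibitor:
- compound 1 `COc1cccc([C@@H]2[C@H](Oc3ccccc3)C(=O)N2c2cc(OC)c(OC)c(OC)c2)c1` gives 171000 nM
- compound 2 `COc1cc(N2C(=O)[C@@H](Oc3ccccc3)[C@H]2c2ccc(C#N)cc2)cc(OC)c1OC` gives 31600 nM
- compound 3 `COc1cc(N2C(=O)[C@@H](Oc3ccccc3)[C@H]2c2ccc([N+](=O)[O-])cc2)cc(OC)c1OC` gives 63000 nM

Compound 1 stands at the highest number of the three in this assay; its nearest neighbour is compound 3, and compound 2 lies furthest from it. The two measured steps away from compound 1 both lower the number: a 5.4-fold lower number from compound 1 to compound 2 (0.73 log units; beyond the scatter) and a 2.7-fold lower number from compound 1 to compound 3 (0.43 log units; beyond the scatter). Between the two para-substituted analogues the difference is small, a 2.0-fold higher number from compound 2 to compound 3 (0.30 log units; within the scatter).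

Compound 4 `COc1cc(N2C(=O)[C@@H](Oc3ccccc3)[C@H]2c2ccc(O)cc2)cc(OC)c1OC` is the next member, and it differs from compound 1 as follows: 4-hydroxyphenyl in place of 3-methoxyphenyl on a saturated ring carbon

Among the compounds with values here, no measured step brings in a hydroxyl group, so the bearing of the earlier steps is indirect. They show only that replacing the 3-methoxyphenyl on this saturated ring carbon with a para-substituted phenyl has so far lowered the number by a modest amount, in compound 2 and in compound 3. Going by these compounds, on that footing the expectation for compound 4 in this assay is a modest lowering of the number relative to compound 1, a 2.1-fold lower number from compound 1 to compound 4 (0.33 log units; beyond the scatter), with the uncertainty wide because the hydroxyl group is untested here. Compound 4 is therefore estimated at 80000 nM, in a range from 30000 nM to 200000 nM.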

Compound 4, half-maximal inhibitory concentration: 48000 nM
The estimate for compound 4 lay 1.7-fold (0.22 log units) above the measured number, within the range that was stated.
By their numbers in this assay, from the lowest: compounds 2, 4 and 3 (each within the scatter of the next); then compound 1.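

In this assay, 4-hydroxyphenyl in place of 3-methoxyphenyl on the saturated ring carbon gives a 3.6-fold lower number from compound 1 to compound 4 (0.55 log units; beyond the scatter), so the modest step from compound 1 also holds with a hydrogen-bond donor in the entering group, and no listed replacement at this position goes against it. On the aromatic carbon, the hydroxy group cannot be separated from the other two groups, with a 1.3-fold lower number from compound 3 to compound 4 (0.12 log units; within the scatter) and a 1.5-fold higher number from compound 2 to compound 4 (0.18 log units; within the scatter), so the nitrile, nitro and hydroxy analogues form a single level within the scatter despite the different groups they carry. No supporting data bear on why this position responds in this way.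

Each step away from compound 1 changes both the group on the phenyl ring and where that group stands, so the compounds shown do not separate these two changes. Going by these compounds, it remains open whether an amine or a carboxylic acid on the same aromatic carbon would stay at this level, and whether any change to the phenoxy group next to this ring carbon's neighbour would move the number further.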